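Fluoro to Methoxy on the Benzyl Ring: Little Change Expected

A few compounds are considered here, and "the series" means these few. Any claim that something is new, unique, unknown or untested is made for them only; others in the source may bear on it.

Compound 1 `Nc1cc(N)c2nc(-c3ccccc3)c(NCc3ccc(Cl)c(Cl)c3)nc2c1` gives 1620 nM in a functional assay on SR cells (Homo sapiens) for inhibition, read by sulforhodamine B assay, with a stated time of 48 h; a lower number here means a stronger inhibitor of growth, a higher number a weaker inhibitor of growth.
Compound 2 `COc1ccc(CNc2nc3cc(N)cc(N)c3nc2-c2ccccc2)cc1OC` gives 3310 nM in this assay.
Compound 3 `Nc1cc(N)c2nc(-c3ccccc3)c(NCc3ccc(F)cc3)nc2c1` gives 4070 nM in this assay.

Compound 3 carries the highest of the three numbers, yet its distance from compound 2 is small and within the scatter, a 1.2-fold higher number from compound 2 to compound 3 (0.09 log units; within the scatter), so the two cannot be ranked. Only compound 1 stands clearly apart, a 2.5-fold higher number from compound 1 to compound 3 (0.40 log units; beyond the scatter), and compound 1 also sits apart from compound 2, a 2.0-fold higher number from compound 1 to compound 2 (0.31 log units; beyond the scatter).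

Compound 4 `COc1ccc(CNc2nc3cc(N)cc(N)c3nc2-c2ccccc2)cc1` differs from compound 3 by methoxy in place of fluoro on an aromatic carbon. Among the measured compounds shown here, the measured step that bears most directly on this is the one from compound 2 to compound 3, a 1.2-fold higher number from compound 2 to compound 3 (0.09 log units; within the scatter), where a ring bearing two methoxy groups was replaced by a ring bearing one fluoro, and the number barely moved. For the measured compounds named here, no measured pair compares a single methoxy with a single fluoro, so the guidance is indirect. The expected step in this assay for compound 4 is therefore small, if anything slightly toward a lower number, a 1.2-fold lower number from compound 3 to compound 4 (0.07 log units; within the scatter). The estimate for compound 4 is 3500 nM, expected to fall between 1600 nM and 7500 nM.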

Compound 4, concentration for 50% growth inhibition: 4070 nM
Compound 4: the middle estimate sits 1.2-fold (0.07 log units) below what was measured; the measured number falls inside the stated range.
By their numbers in this assay, from the lowest: compound 1; then compounds 2, 3 and 4 (each within the scatter of the next).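

In this assay, among the compounds shown here, this is the first direct comparison of a single methoxy with a single fluoro at this place on the ring, and the two groups cannot be told apart (no change at the digits printed from compound 3 to compound 4 (within the scatter)), even though methoxy adds one heavy atom and one hydrogen-bond acceptor. The second methoxy of the 3,4-dimethoxyphenyl ring can also go without a step beyond the scatter (a 1.2-fold higher number from compound 2 to compound 4 (0.09 log units; within the scatter)), while the 3,4-dichlorophenyl of compound 1 still stands apart from this ring (a 2.5-fold higher number from compound 1 to compound 4 (0.40 log units; beyond the scatter)). Nothing shown here explains why these groups give such similar numbers.

Going by these compounds, it remains open whether a single chloro at this place would match the 3,4-dichlorophenyl ring or whether both chlorines are needed. Also open, on these data alone, is how an amine or a carboxylic acid here would read in this assay.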